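This account rests on a few compounds, and the source may have more. Where it says the series, first, only, none or still open, it means among the compounds named here.

Of the compounds shown here, two that share one core have numbers so far in a functional assay on MCF7 cells (Homo sapiens) for cytotoxicity, read by MTT assay, with a stated time of 48 h; a higher number here means a weaker inhibitor, a lower number a stronger inhibitor. Compound 1 `Cc1ccc(/C=C2/S/C(=N/c3ccccc3)N(Cc3ccncc3)C2=O)cc1` gives 36900 nM, and compound 2 `CN(C)c1ccc(/C=C2/S/C(=N/c3ccccc3)N(Cc3ccncc3)C2=O)cc1` gives 76300 nM, which makes compound 2 the higher, and so weaker, of the two. Compound 3 `O=C1/C(=C\c2ccc(O)c(O)c2)S/C(=N/c2ccccc2)N1Cc1ccncc1` has not been measured yet. It differs from compound 2 as follows: 3,4-dihydroxyphenyl in place of 4-(dimethylamino)phenyl on a double-bonded chain carbon bound to a double-bonded ring carbon. Put simply, 3,4-dihydroxyphenyl stands in place of 4-(dimethylamino)phenyl on a double-bonded chain carbon bound to a double-bonded ring carbon.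

Going by the values given here, only one measured step bears on this change: a 2.1-fold higher number from compound 1 to compound 2 (0.32 log units; beyond the scatter). It is modest, and it came from dimethylamino in place of methyl on an aromatic carbon. Among the compounds with values here, no measured compound carries 3,4-dihydroxyphenyl, so this step is a rough guide to size and a weak guide to direction. With compound 2 at 76300 nM, the top of the measured numbers, a modest move downward seems the likelier outcome. The expected step is a 2.2-fold lower number from compound 2 to compound 3 (0.34 log units; beyond the scatter). For compound 3 the estimated value is 35000 nM, with an expected range from 10000 nM to 100000 nM.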

Compound 3, half-maximal inhibitory concentration: 12400 nM
Estimate against measurement, compound 3: 2.8-fold (0.45 log units) above; the measured number falls inside the stated range.
By their numbers in this assay, from the lowest: compound 3; then compound 1; then compound 2.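

In this assay, the aromatic group on the double-bonded chain carbon bound to a double-bonded ring carbon can be exchanged with a clear gain: 3,4-dihydroxyphenyl gives a 6.2-fold lower number from compound 2 to compound 3 (0.79 log units; beyond the scatter) and, against the methyl-bearing ring, a 3.0-fold lower number from compound 1 to compound 3 (0.47 log units; beyond the scatter) in the same direction. Compound 3 is therefore the strongest of the three, whereas the two earlier compounds showed only how the number moved between 4-methylphenyl and 4-(dimethylamino)phenyl, neither of which carries a hydroxyl group. Nothing measured here explains why the 3,4-dihydroxyphenyl compound gives the lowest number.

Going by these compounds, what remains open is whether both hydroxyl groups are needed, since a phenyl ring with a single hydroxyl, or with two methoxy groups in their place, would separate the effect of each group from that of the pair. The three compounds also share everything else, so they cannot show whether the same exchange would hold if the pyridine-free parts of the molecule changed, for instance with a carboxylic acid on the phenyl ring of the imine.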